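A few compounds are considered here, and "the series" means these few. Any claim that something is new, unique, unknown or untested is made for them only; others in the source may bear on it.

Compound 2 `C[C@H](Oc1ccc(S(C)(=O)=O)cc1C(=O)N1Cc2ccc(-c3ccccn3)cc2C1)C(F)(F)F`: 84 nM
Compound 1 `C[C@H](Oc1ccc(S(C)(=O)=O)cc1C(=O)N1Cc2ccc(N3CCN(C)CC3)cc2C1)C(F)(F)F`: 2080 nM

Going by the values given here, compound 2 gives the lower of the two numbers measured so far in an assay on CHO cells for inhibition of sodium- and chloride-dependent glycine transporter 1 (Homo sapiens), read by scintillation counting; a higher number here means that more compound is needed for the effect, a lower number that less compound is needed; its nearest neighbour is compound 1, which gives 2080 nM, and the single step between measured compounds, a 25-fold lower number from compound 1 to compound 2 (1.39 log units; beyond the scatter), is large and beyond the scatter. Compound 3 `C[C@H](Oc1ccc(S(C)(=O)=O)cc1C(=O)N1Cc2ccc(-c3ccncc3)cc2C1)C(F)(F)F` is the compound still to be measured, and the change from compound 2 is pyridin-4-yl in place of pyridin-2-yl on an aromatic carbon. Among the compounds with values here, no measured step compares two pyridinyl isomers: the step of a 25-fold lower number from compound 1 to compound 2 (1.39 log units; beyond the scatter) exchanges 4-methylpiperazin-1-yl for pyridin-2-yl, a different kind of change, so it bears only loosely on the move from compound 2 to compound 3. The expectation for compound 3 is therefore a step of a 1.8-fold higher number from compound 2 to compound 3 (0.25 log units; within the scatter), smaller than the measured one and possibly within the scatter. The estimate for compound 3 is 150 nM, in a range from 50 nM to 500 nM.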

Compound 3, half-maximal effective concentration in the sodium- and chloride-dependent glycine transporter 1 assay: 17 nM
Compound 3: the middle estimate sits 8.8-fold (0.95 log units) above what was measured; measured number below the stated range.
By their numbers in the sodium- and chloride-dependent glycine transporter 1 assay, from the lowest: compound 3; then compound 2; then compound 1.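

In the sodium- and chloride-dependent glycine transporter 1 assay compound 2 gives 84 nM and compound 3 gives 17 nM and swapping pyridin-2-yl for pyridin-4-yl, two groups with the same atoms and the same counts of donors and acceptors, gives a 4.9-fold lower number from compound 2 to compound 3 (0.69 log units; beyond the scatter) and so shows that this position responds to where the nitrogen sits in the attached ring, not only to the kind of ring placed there. Against the 4-methylpiperazin-1-yl group, the gap in the sodium- and chloride-dependent glycine transporter 1 assay now widens to a 120-fold lower number from compound 1 to compound 3 (2.09 log units; beyond the scatter) and stays large. In a physicochemical assay for solubility (a lower number here means a less soluble compound, a higher number a more soluble compound), compound 2 gives 30 ug/mL and compound 3 gives 25 ug/mL so the same isomer change gives a 1.2-fold lower number from compound 2 to compound 3 (0.08 log units; within the scatter) and does not separate the two.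

The compounds shown leave open how pyridin-3-yl, or a plain phenyl ring with no ring nitrogen, would fare at this position. Why the two pyridinyl isomers differ also stays open, as nothing here accounts for it.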